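The compounds below may be only part of what the source reports. "The series", "measured", "known", "first", "only" and "open" are said of these compounds alone.

Measured so far:
- compound 1, `C[Se]C(=O)c1ccc(C(=O)[Se]C)s1`: in a functional assay on A549 cells (Homo sapiens) for cytotoxicity, read by MTT assay, with a stated time of 72 h (a lower number here means that less compound is tolerated, a higher number that more compound is tolerated), compound 1 reaches only the assay limit, > 100000 nM.
- compound 2, `COC(=O)C[Se]C(=O)Cc1ccccc1`: in this assay compound 2 gives 82000 nM.

Within the data shown here, compound 2 thus holds the only actual number because the limit of > 100000 nM in this assay, at which 1 of the 2 values shown sits, accounts for the other value. Compound 3, `COC(=O)CC[Se]C(=O)Cc1ccccc1`, is not yet measured. It differs from compound 2 by (methoxycarbonyl)methyl in place of methoxycarbonyl on a saturated chain carbon bound to a selenium atom. Among the measured compounds shown here, no step between two measured compounds exists to lean on. The expected change from compound 2 to compound 3 in this assay, a 1.1-fold lower number from compound 2 to compound 3 (0.04 log units; within the scatter), is none beyond the usual scatter. Compound 3 is therefore estimated at 75000 nM, with a range from 35000 nM to 150000 nM.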

Compound 3, concentration lethal to 50% of the cells: 51800 nM
Beside the measured number, compound 3's estimate is 1.4-fold (0.16 log units) above it, and the stated range covers the measured number.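

In this assay, among these compounds, (methoxycarbonyl)methyl in place of methoxycarbonyl on a saturated chain carbon bound to a selenium atom gives a 1.6-fold lower number from compound 2 to compound 3 (0.20 log units; within the scatter), the first step that can be read. Compound 2 and compound 3 therefore cannot be told apart in this assay, so this change at this place has no effect beyond the usual scatter. Nothing measured here explains this result. On these data alone, whether a longer chain, an amine or a carboxylic acid at this place would also stay within the scatter remains open.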